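Pendant aryl swap on compound 1: furan to pyridine

The source may hold more compounds than are shown below. What is called first, only, known or untested is meant among the compounds shown, and "the series" means these compounds.

In a functional assay on PC-3 cells (Homo sapiens) for antiproliferative activity, read by CCK-8 assay, with a stated time of 6 days (on this read-out higher numbers stand for weaker inhibition and lower numbers for stronger inhibition), compound 1 `CCN(c1ccc(C#N)c(Cl)c1)c1cc(-c2ccoc2)ccc1C` returns only the assay limit, > 30000 nM. Compound 2 `CCN(c1ccc(C#N)c(C(F)(F)F)c1)c1cc(-n2ccnc2)ccc1C` likewise reports only a limit in this assay, > 30000 nM. For compound 3 `N#Cc1ccc(N2CCc3cc(-c4cncnc4)ccc3C2)cc1C(F)(F)F` the entry in this assay reads "not determined" (no result reported), so no result is available for it. Compound 1 therefore stands at the limit of > 30000 nM in this assay, at which 2 of the 3 values shown sit, with no numeric value to rank it against any other member. Compound 4 `CCN(c1ccc(C#N)c(Cl)c1)c1cc(-c2ccncc2)ccc1C` differs from compound 1 by a single change: pyridin-4-yl in place of furan-3-yl on an aromatic carbon. Within the data shown here, no measured step of this kind exists, so the expectation rests only on the limit of compound 1. The step is expected to be an at least 1.5-fold lower number from compound 1 to compound 4 (0.17 log units; that floor lies within the scatter), modest and not clearly beyond the scatter. Compound 4 is estimated at 20000 nM in this assay, within a range of 3000 nM to 60000 nM.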

Compound 4, half-maximal inhibitory concentration: 3580 nM
Compound 4: middle estimate off by 5.6-fold (0.75 log units), on the high side; low and high end bracket the measured number.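

Pyridin-4-yl in place of furan-3-yl, on the aromatic carbon meta to a large group and para to a methyl group, gives an at least 8.3-fold lower number from compound 1 to compound 4 (0.92 log units; beyond the scatter). This shows that the pendant ring at this position can move this assay from the limit to a measured number. Compound 4 is the only compound shown with such a number, and the step is a floor, not an exact size: the limit of > 30000 nM in this assay, at which 2 of the 4 values shown sit.

From the compounds shown here alone, whether phenyl or pyridin-3-yl at this carbon would give a similar number remains open. Compound 2 differs from compound 4 in more than one place, so the two cannot be compared.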